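Methyl on the Pyridine Ring of an Amidrazone Thiosemicarbazide

The compounds below may be only part of what the source reports. "The series", "measured", "known", "first", "only" and "open" are said of these compounds alone.

Of the compounds shown here, two have been measured in a functional assay on A-431 cells (Homo sapiens) for cytotoxicity, read by MTT assay, with a stated time of 72 h, tested at 3 uM; on this read-out higher numbers stand for more inhibition of growth at the one concentration tested and lower numbers for less inhibition of growth. Compound 1 `N/C(=N\NC(=S)N1CCCCCC1)c1ccccn1` gives 50.3%, and compound 2 `N/C(=N\NC(=S)N1CCOCC1)c1ccccn1` gives 43.1%; the two numbers lie within the usual scatter of each other, so nothing separates them. Compound 3 `Cc1ccnc(/C(N)=N/NC(=S)N2CCOCC2)c1` differs from compound 2 by methyl in place of hydrogen on an aromatic carbon. For the measured compounds named here, with no comparable step among the measured compounds, the author expects the change from compound 2 to compound 3 to bring no shift beyond the scatter, that is a number 1.9 percentage points higher from compound 2 to compound 3 (within the scatter). Compound 3 is therefore estimated at 45%, in a range from 30% to 60%.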

Compound 3, percent growth inhibition at one concentration: 35.5%
Estimate against measurement, compound 3: 9.5 percentage points above; measured number inside the range.
By their numbers in this assay, from the lowest: compounds 3, 2 and 1 (each within the scatter of the next, the first and the last beyond it).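

The earlier compounds shown here carry hydrogen at this place on the aromatic ring, and in this assay methyl there, opposite the ring nitrogen, gives a number 7.6 percentage points lower from compound 2 to compound 3 (within the scatter) and so stays inside the scatter. This single change therefore does not separate compound 3 from compound 2 on this read-out. Nothing at hand bears on what lies behind this result.

Still open, on these data alone, is whether a longer chain such as ethyl, an amine or a carboxylic acid at this same place would move the growth inhibition beyond the scatter. As far as these compounds go, it is also open whether methyl here would behave alike on the core of compound 1.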